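Swapping the Amide Aryl Group on a Purinoceptor Antagonist Core

The source may hold more compounds than are shown below. What is called first, only, known or untested is meant among the compounds shown, and "the series" means these compounds.

Two compounds have been measured in an assay on HEK293 cells for antagonist activity at P2X purinoceptor 7 (Homo sapiens), read by fluorescence, with a stated time of 2 h; a higher number here means a weaker inhibitor, a lower number a stronger inhibitor:
Compound 1, `COc1ccc(C(=O)N2CCC(n3cncc3-c3ccc(OS(=O)(=O)c4cccc5cnccc45)cc3)CC2)cc1`, gives 77 nM.
Compound 2, `COc1ccc(C(=O)N2CCC(n3cncc3-c3ccc(OS(=O)(=O)c4cccc5cnccc45)cc3)CC2)cc1OC`, gives 259 nM.

Compound 2 has the higher of the two numbers, so it is the weaker inhibitor of the pair. Among the compounds with values here, the only measured step shows a 3.4-fold higher number from compound 1 to compound 2 (0.53 log units; beyond the scatter), a modest loss that lies beyond the scatter.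

Compound 3, `CS(=O)(=O)c1ccc(C(=O)N2CCC(n3cncc3-c3ccc(OS(=O)(=O)c4cccc5cnccc45)cc3)CC2)cc1`, has not yet been measured. It differs from compound 2 in one place: 4-(methylsulfonyl)phenyl in place of 3,4-dimethoxyphenyl on a carbonyl carbon. This change both removes the extra methoxy that cost activity in compound 2 and replaces the remaining methoxy, so only part of it is covered by the measured step. On these data alone, because the step from compound 1 to compound 2 shows a 3.4-fold higher number from compound 1 to compound 2 (0.53 log units; beyond the scatter), removing that second methoxy alone would be expected to recover most of that loss; what the methylsulfonyl adds on top is unknown from these data. Compound 3 is therefore estimated to show a 2.2-fold lower number from compound 2 to compound 3 (0.33 log units; beyond the scatter), with a wide range. The expected value for compound 3 is 120 nM, between 35 nM and 400 nM.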

Compound 3, half-maximal inhibitory concentration: 25 nM
Estimate against measurement, compound 3: 4.8-fold (0.68 log units) above; measured number below the stated range.
By their numbers in this assay, from the lowest: compound 3; then compound 1; then compound 2.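

In this assay, within the data shown here, the aryl group on the carbonyl carbon proves able to gain activity as well as lose it: methylsulfonyl in place of methoxy on an aromatic carbon gives a 3.1-fold lower number from compound 1 to compound 3 (0.49 log units; beyond the scatter), whereas the only earlier step was a loss. The full exchange of 3,4-dimethoxyphenyl for 4-(methylsulfonyl)phenyl gives a 10-fold lower number from compound 2 to compound 3 (1.02 log units; beyond the scatter), a large step that shows how strongly this one group can set the result, even though both groups count 10 heavy atoms and 2 hydrogen-bond acceptors, so those counts do not separate them. The data offer no measurement that explains why the methylsulfonyl compound is the stronger inhibitor.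

The compounds shown leave open whether the gain is particular to methylsulfonyl or would also appear with a nitrile, a sulfonamide or a carboxylic acid on the same phenyl ring. They also leave open whether a longer chain on the sulfur, such as ethylsulfonyl, would keep the activity of compound 3, and whether this gain would carry over if the rest of the shared core were changed.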